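This account rests on a few compounds, and the source may have more. Where it says the series, first, only, none or still open, it means among the compounds named here.

Measured so far in a functional assay on HeLa cells (Homo sapiens) for cytotoxicity, read by MTT assay, with a stated time of 24 h; on this read-out higher numbers stand for weaker inhibition and lower numbers for stronger inhibition:

Compound 1 `CNC(=O)Cn1nc(N)c2c(C(F)(F)F)cc(-c3ccccc3)nc21` gives 12200 nM.
Compound 2 `CCNC(=O)Cn1nc(N)c2c(C(F)(F)F)cc(-c3ccccc3)nc21` gives 20200 nM.
Compound 3 `Nc1nn(CC(=O)NCC(=O)O)c2nc(-c3ccccc3)cc(C(F)(F)F)c12` gives 19100 nM.

All three share the core of compound 1; compound 3 differs from it by carboxy in place of hydrogen on a saturated chain carbon bound to an amide-type nitrogen. Within the data shown here, the one change already seen twice here is methyl in place of hydrogen on a saturated chain carbon bound to an amide-type nitrogen, which gave a 1.7-fold higher number from compound 1 to compound 2 (0.22 log units; within the scatter) in this assay. Compound 4 `CC(NC(=O)Cn1nc(N)c2c(C(F)(F)F)cc(-c3ccccc3)nc21)C(=O)O` stands to compound 3 as compound 2 stands to compound 1, by methyl in place of hydrogen on a saturated chain carbon bound to an amide-type nitrogen and a carbonyl carbon. The two places are not identical: in compound 1 the chain carbon is bound to an amide-type nitrogen only, in compound 3 it is bound to an amide-type nitrogen and a carbonyl carbon, so this is the same kind of change rather than the same change. Among the measured compounds shown here, with only one prior instance, the step from compound 3 to compound 4 is expected at about a 1.3-fold higher number from compound 3 to compound 4 (0.12 log units; within the scatter), resting on compound 1 to compound 2 giving a 1.7-fold higher number from compound 1 to compound 2 (0.22 log units; within the scatter). For compound 4 the expected value in this assay is 25000 nM, between 10000 nM and 60000 nM.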

Compound 4, half-maximal inhibitory concentration: 20100 nM
Compound 4: middle estimate off by 1.2-fold (0.09 log units), on the high side; the range from low to high includes it.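

Methyl in place of hydrogen gives a 1.1-fold higher number from compound 3 to compound 4 (0.02 log units; within the scatter) on the carboxy-bearing chain, which agrees with the earlier step: the same change on two cores in this assay, a 1.7-fold higher number (0.22 log units; within the scatter) from compound 1 to compound 2 and a 1.1-fold higher number (0.02 log units; within the scatter) from compound 3 to compound 4, 1.6-fold (0.20 log units) apart, within the scatter of two such steps. Carboxy in place of hydrogen gives a 1.0-fold lower number from compound 2 to compound 4 (0.00 log units; within the scatter), which also agrees with the earlier step: the same change on two cores in this assay, a 1.6-fold higher number (0.19 log units; within the scatter) from compound 1 to compound 3 and a 1.0-fold lower number (0.00 log units; within the scatter) from compound 2 to compound 4, 1.6-fold (0.20 log units) apart, within the scatter of two such steps. In this assay, 1-carboxyethyl in place of methyl on the amide-type nitrogen gives a 1.6-fold higher number from compound 1 to compound 4 (0.22 log units; within the scatter); with all of these steps inside the scatter, the two changes show no difference between cores, but this does not show that a real effect carries over, since none is resolved here.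

On these data alone, it remains open whether a longer chain in place of the methyl, or an amine or an ester in place of the carboxy, gives a step beyond the scatter.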